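Removing the Butoxy Group from a Quinolinol Amide

This account rests on a few compounds, and the source may have more. Where it says the series, first, only, none or still open, it means among the compounds named here.

Measured compounds:
Compound 1 `O=C(NC(c1ccc(Cl)cc1Cl)c1ccc2cccnc2c1O)C1CCCC1` — 150 nM
Compound 2 `CCCCOc1ccnc2c(O)c(CNC(=O)C3CCCCC3)ccc12` — 510 nM

In a functional assay on Daoy cells (Homo sapiens) for antiproliferative activity, read by trypan blue exclusion and crystal violet staining, with a stated time of 72 h (a higher number here means a weaker inhibitor, a lower number a stronger inhibitor), compound 1 gives 150 nM, while compound 2 gives 510 nM. Compound 2 thus stands at the higher of the two numbers, and the gap to compound 1 is beyond the scatter of this assay. The two compounds differ in more than one place, so no single change accounts for that gap.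

Compound 3 `O=C(NCc1ccc2cccnc2c1O)C1CCCCC1` is the unmeasured member of the set. It differs from compound 2 by hydrogen in place of butoxy on an aromatic carbon. For the measured compounds named here, no measured pair in this set isolates such a change, so the size of the step cannot be drawn from the data. The estimate for compound 3 in this assay is 750 nM, with a range of 250 nM to 2500 nM. The step this estimate implies, from compound 2 to compound 3, is a 1.5-fold higher number from compound 2 to compound 3 (0.17 log units; within the scatter), expected to be a modest loss, possibly within the scatter.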

Compound 3, half-maximal inhibitory concentration: 720 nM
Beside the measured number, compound 3's estimate is 1.0-fold (0.02 log units) above it; the range from low to high includes it.
By their numbers in this assay, from the lowest: compound 1; then compounds 2 and 3 (each within the scatter of the next).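

In this assay, for the compounds shown here, hydrogen in place of butoxy on an aromatic carbon, opposite the ring nitrogen, gives a 1.4-fold higher number from compound 2 to compound 3 (0.15 log units; within the scatter), the first step in this set that isolates a single change. At this position, then, the butoxy group can be removed entirely without a change that rises above the scatter, so compound 2 and compound 3 cannot be told apart in this test. No available evidence explains this result.

The compounds shown leave open whether other groups at this position, such as an amine, a carboxylic acid or a chain longer than butoxy, would also leave the number within the scatter or move it beyond. They also leave open whether the same replacement would give a similar step on the core of compound 1.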